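The source may hold more compounds than are shown below. What is called first, only, known or untested is meant among the compounds shown, and "the series" means these compounds.

Compound 1 `C=CCn1c(=O)/c(=C\c2cc(F)ccc2C)[nH]c(=O)/c1=C\c1ccccc1OC` stands highest of the two numbers measured in a functional assay on MCF7 cells (Homo sapiens) for cytotoxicity, read by CCK-8 assay, with a stated time of 72 h (a lower number here means a stronger inhibitor, a higher number a weaker inhibitor), where compound 1 gives 3100 nM. The nearest number belongs to compound 2 `COc1ccccc1/C=c1\c(=O)[nH]/c(=C/c2ccccc2Cl)c(=O)n1C`, which in this assay gives 200 nM, a gap beyond the usual scatter. Compound 3 `C=CCn1c(=O)/c(=C\c2ccccc2C(F)(F)F)[nH]c(=O)/c1=C\c1ccccc1OC` has not yet been measured. It differs from compound 1 in one place: 2-(trifluoromethyl)phenyl in place of 5-fluoro-2-methylphenyl on a double-bonded chain carbon bound to an aromatic carbon. For the measured compounds named here, no step between measured compounds isolates this change, so its size is not known from data. The step is expected to be small and downward, a 1.6-fold lower number from compound 1 to compound 3 (0.19 log units; within the scatter), perhaps not beyond the scatter. Compound 3 is expected to give about 2000 nM in this assay, within a range from 600 nM to 6500 nM.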

Compound 3, half-maximal inhibitory concentration: 6500 nM
For compound 3 the middle estimate is 3.3-fold (0.51 log units) below the measured one, and the stated range covers the measured number.
By their numbers in this assay, from the lowest: compound 2; then compound 1; then compound 3.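

In this assay, 2-(trifluoromethyl)phenyl in place of 5-fluoro-2-methylphenyl on a double-bonded chain carbon bound to an aromatic carbon gives a 2.1-fold higher number from compound 1 to compound 3 (0.32 log units; beyond the scatter), a modest step and the first one read at this place. The number at this place therefore responds to the choice of aromatic group, and this change moves it towards a weaker inhibitor. Nothing available accounts for the step.

From the compounds shown here alone, the share of each part of the exchanged group remains open, as does the outcome with an amine or a carboxylic acid on this aromatic ring.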